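Furan Ring at the Saturated Carbon of a Shared Core

A few compounds are considered here, and "the series" means these few. Any claim that something is new, unique, unknown or untested is made for them only; others in the source may bear on it.

Measured compounds:
compound 1, `O=C1N=C(C2C(=O)c3ccccc3C2=O)CC(c2ccc([N+](=O)[O-])cc2)N1`, 26%
compound 2, `O=C1N=C(C2C(=O)c3ccccc3C2=O)CC(c2ccccc2O)N1`, 22%

Of the compounds shown here, two have been tested in a functional assay on the whole organism for inhibition, with Rattus norvegicus as the target, read by paw edema, with stated times of 30 min and 2 h, at a dose of 10 mg/kg by the oral route; a lower number here means less inhibition, a higher number more inhibition at the dose given (going by the name of the read-out). Compound 1 gives 26%, and compound 2 gives 22%. Between them lies one structural change, and the step of a number 4 percentage points lower from compound 1 to compound 2 (within the scatter) shows the two numbers sit close together. Compound 2 has the lower of the two numbers, but since its gap to compound 1 is within the scatter, no order between the two can be claimed.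

Compound 3, `O=C1N=C(C2C(=O)c3ccccc3C2=O)CC(c2ccco2)N1`, is the next compound to be measured in this assay. It differs from compound 2 in one place: furan-2-yl in place of 2-hydroxyphenyl on a saturated ring carbon. Within the data shown here, the only measured step available for comparison is the one from compound 1 to compound 2, which changed the same position and stayed within the scatter. Among the measured compounds shown here, no step involving a furan ring has been measured, so the expectation rests on that single comparison. Compound 3 is therefore expected to stay near compound 2, with an estimated step of no change at the digits printed from compound 2 to compound 3 (within the scatter). Compound 3 is estimated to give 22%, expected to fall between 10% and 34%.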

Compound 3, a percentage reported as inhibition, in the whole organism at one dose (the size of the read-out at that dose, not a potency): 25%
Compound 3: middle estimate off by 3 percentage points, on the low side; the range from low to high includes it.
By their numbers in this assay, from the lowest: compounds 2, 3 and 1 (each within the scatter of the next).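

In this assay, furan-2-yl in place of 2-hydroxyphenyl on the saturated ring carbon gives a number 3 percentage points higher from compound 2 to compound 3 (within the scatter) and furan-2-yl in place of 4-nitrophenyl gives a number 1 percentage points lower from compound 1 to compound 3 (within the scatter) at the same place. This position, next to the ring nitrogen, has now carried a five-membered aromatic ring with 1 hetero atom as well as a six-membered aromatic ring of carbon only, and the three compounds read alike within the scatter. That also holds for a change from a group with 1 hydrogen-bond donor to one with 0 hydrogen-bond donors, though no accompanying measurement accounts for these numbers.

All the groups shown at this position are aromatic rings, so it remains open what a cyclohexyl ring, a longer alkyl chain or a primary amine would give there. None of the steps shown goes beyond the scatter, and whether any group at this position can do so is unanswered.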